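The compounds below may be only part of what the source reports. "The series", "measured", "known", "first", "only" and "open" are said of these compounds alone.

Compound 1 `COc1ccc(-c2nc3ccccn3c2C(=O)/C=C\Nc2ccc3cc[nH]c3c2)cc1` gives 8800 nM in a functional assay on A549 cells (Homo sapiens) for cytotoxicity, read by MTT assay, with a stated time of 48 h (a higher number here means a weaker inhibitor, a lower number a stronger inhibitor), and stands as the higher of the two numbers in hand; compound 2 `COc1ccc(-c2nc3ccccn3c2C(=O)/C=C\Nc2ccc3ncccc3c2)cc1` gives 1210 nM, a step of a 7.3-fold lower number from compound 1 to compound 2 (0.86 log units; beyond the scatter) for quinolin-6-yl in place of 1H-indol-6-yl on an amine nitrogen. Compound 3 `O=C(/C=C\Nc1ccc2cc[nH]c2c1)c1c(-c2ccc(Cl)cc2)nc2ccccn12` differs from compound 1 elsewhere: chloro in place of methoxy on an aromatic carbon. For the measured compounds named here, no measured step touches this place; the single known step concerns the amine nitrogen and offers no guide. A step beyond the scatter in this assay is therefore not expected in either direction. For compound 3 the expected number is 7500 nM (range 2500 nM to 22000 nM), an expected step of a 1.2-fold lower number from compound 1 to compound 3 (0.07 log units; within the scatter).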

Compound 3, half-maximal inhibitory concentration: 2290 nM
For compound 3 the middle estimate is 3.3-fold (0.52 log units) above the measured one; measured number outside the range, below it.
By their numbers in this assay, from the lowest: compounds 2 and 3 (each within the scatter of the next); then compound 1.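

The place on the aromatic ring para to a large group is now shown to affect the number: in this assay, chloro in place of methoxy gives a 3.8-fold lower number from compound 1 to compound 3 (0.58 log units; beyond the scatter) with the 1H-indol-6-yl group kept on the amine nitrogen. The series therefore responds at this second place as well as at the amine nitrogen, although this reading rests on a single pair. Nothing at hand accounts for the step. As far as these compounds go, whether the change carries over to the quinolin-6-yl compound 2 remains open. So does how a fluoro, trifluoromethyl or dimethylamino group would read at this place.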